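Swapping a Halogenated Phenyl Amide for a Pyrazine Amide

This account rests on a few compounds, and the source may have more. Where it says the series, first, only, none or still open, it means among the compounds named here.

Compound 1 `COc1ccc(C(=O)Nc2c(F)cccc2Cl)cc1OC1CCCC1` is the weaker of the two measured compounds: in an assay on isolated protein for inhibition of phosphodiesterase 4A (Sus scrofa) (on this read-out lower numbers stand for stronger inhibition and higher numbers for weaker inhibition), compound 1 gives 240 nM, whereas compound 2 `COc1ccc(C(=O)Nc2c(Cl)cccc2Cl)cc1OC1CC2CCC1C2` gives 10 nM, a gap well beyond the usual scatter. Compound 3 `COc1ccc(C(=O)Nc2cnccn2)cc1OC1CCCC1` differs from compound 1 by pyrazin-2-yl in place of 2-chloro-6-fluorophenyl on an amide-type nitrogen. Among the compounds with values here, no measured pair shows this particular change, so its effect is open. The step is estimated as a 4.2-fold higher number from compound 1 to compound 3 (0.62 log units; beyond the scatter), leaning toward weaker inhibition. Compound 3 is therefore expected to give about 1000 nM, with a plausible range from 200 nM to 5000 nM.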

Compound 3, half-maximal inhibitory concentration: 250 nM
Estimate against measurement, compound 3: 4.0-fold (0.60 log units) above; the range from low to high includes it.
By their numbers in this assay, from the lowest: compound 2; then compounds 1 and 3 (each within the scatter of the next).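

In this assay, pyrazin-2-yl in place of 2-chloro-6-fluorophenyl on the amide-type nitrogen changes nothing beyond the scatter (a 1.0-fold higher number from compound 1 to compound 3 (0.02 log units; within the scatter)). On the core of compound 1, then, this position accepts a ring with 2 hetero atoms and no halogen, so neither chlorine nor fluorine is required to keep this level of inhibition. No measurement shown explains why the two groups match.

On these data alone, whether plain phenyl or pyridin-4-yl would also match remains open. So does whether pyrazin-2-yl would be accepted on the core of compound 2.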